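Chloro on the pendant phenyl across two related cores

A few compounds are considered here, and "the series" means these few. Any claim that something is new, unique, unknown or untested is made for them only; others in the source may bear on it.

Compound 1 `C=C(Br)C(=O)Nc1cccc(-c2cn3nc(Cc4ccccc4)sc3n2)c1` and compound 2 `C=C(Br)C(=O)Nc1cccc(-c2cn3nc(Cc4ccc(Cl)cc4)sc3n2)c1` share one core; compound 3 `C=C(Br)C(=O)Nc1cccc(-c2cn3c(-c4ccccc4)csc3n2)c1` and compound 4 `C=C(Br)C(=O)Nc1cccc(-c2cn3c(-c4ccc(Cl)cc4)csc3n2)c1` share another. The difference between the two cores is not broken down here. In a functional assay on HeLa cells (Homo sapiens) for inhibition, read by cell counting, with a stated time of 4 days (a higher number here means a weaker inhibitor, a lower number a stronger inhibitor), compound 1 gives 4500 nM, and compound 2 gives 2700 nM. The change between them is chloro in place of hydrogen on an aromatic carbon and the step is a 1.7-fold lower number from compound 1 to compound 2 (0.22 log units; within the scatter). Compound 3 gives 3400 nM in this assay, which sits within the scatter of both compound 1 and compound 2. The change from compound 3 to compound 4 is chloro in place of hydrogen on an aromatic carbon, the same change as the one made on the first core, placed in the same way. For compound 4 the step is expected to be a 1.6-fold lower number from compound 3 to compound 4 (0.21 log units; within the scatter), resting on the small step seen between compound 1 and compound 2 in this assay, a 1.7-fold lower number from compound 1 to compound 2 (0.22 log units; within the scatter), with the reservation that this step was itself within the scatter and that the core is not the same. Compound 4 is therefore estimated at 2100 nM in this assay, between 1000 nM and 4500 nM.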

Compound 4, half-maximal inhibitory concentration: 3000 nM
The estimate for compound 4 lay 1.4-fold (0.15 log units) below the measured number; the measured number falls inside the stated range.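

On the core of compound 3, the change from phenyl to 4-chlorophenyl gives a 1.1-fold lower number from compound 3 to compound 4 (0.05 log units; within the scatter) in this assay. Set beside the step on the other core, it shows no difference that stands out from the scatter: the same change on two cores in this assay, a 1.7-fold lower number (0.22 log units; within the scatter) from compound 1 to compound 2 and a 1.1-fold lower number (0.05 log units; within the scatter) from compound 3 to compound 4, 1.5-fold (0.17 log units) apart, within the scatter of two such steps. The two cores are therefore compatible with the change carrying over, but this is agreement between two steps that are each within the scatter, so neither core shows a measurable effect of the chloro and the pair cannot establish a shared effect of any particular size.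

Still open, as far as these compounds go, is whether a different group in the place of the chloro, such as an amine, a carboxylic acid or a methoxy group, would give a step beyond the scatter on either core. Also open, from the compounds shown here alone, is whether chloro in place of hydrogen would behave in the same way on a third core or in an assay other than this assay.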